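A few compounds are considered here, and "the series" means these few. Any claim that something is new, unique, unknown or untested is made for them only; others in the source may bear on it.

Working notes on the series in an ADME assay on RAW264.7 cells (Mus musculus) for cytotoxicity, read by MTT assay, with a stated time of 48 h; a lower number here means that less compound is tolerated, a higher number that more compound is tolerated. Three measured compounds share one core and differ in the group on the thiourea-type end: compound 1 `S=C(N/N=C\c1ccnc2ccccc12)Nc1cccnc1`, compound 2 `CCc1ccc(NC(=S)N/N=C\c2ccnc3ccccc23)cc1` and compound 3 `O=[N+]([O-])c1ccc(NC(=S)N/N=C\c2ccnc3ccccc23)cc1`. Compound 1 gives 91600 nM, compound 2 gives 35700 nM and compound 3 gives 82500 nM. Compound 3 thus lies within the scatter of compound 1, and only compound 2 stands apart, with a clearly lower number.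

The next compound is compound 4 `S=C(N/N=C\c1ccnc2ccccc12)Nc1ccc(Cl)cc1`, with chloro in place of nitro on an aromatic carbon, para to a large group: chloro in place of nitro on an aromatic carbon. Among the compounds with values here, the one measured change at this carbon is a 2.3-fold higher number from compound 2 to compound 3 (0.36 log units; beyond the scatter), and it is modest. The wider exchange of the whole aromatic group, a 2.6-fold lower number from compound 1 to compound 2 (0.41 log units; beyond the scatter), is also modest. Within the data shown here, no chloro compound has been measured, so neither step gives its size directly. A small step towards a lower number is expected, perhaps not beyond the scatter, with the result lying within the span the three measured compounds cover. The expected change is a 1.5-fold lower number from compound 3 to compound 4 (0.18 log units; within the scatter). Compound 4 is estimated at 55000 nM, with an expected range of 28000 nM to 105000 nM.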

Compound 4, half-maximal cytotoxic concentration: 63500 nM
For compound 4 the middle estimate is 1.2-fold (0.06 log units) below the measured one; measured number inside the range.
By their numbers in this assay, from the lowest: compounds 2, 4, 3 and 1 (each within the scatter of the next, the first and the last beyond it).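

In this assay, chloro in place of nitro on this aromatic carbon, para to a large group, gives a 1.3-fold lower number from compound 3 to compound 4 (0.11 log units; within the scatter), and chloro in place of ethyl gives a 1.8-fold higher number from compound 2 to compound 4 (0.25 log units; within the scatter). Ethyl and nitro had been separated at this carbon by a 2.3-fold higher number from compound 2 to compound 3 (0.36 log units; beyond the scatter), whereas chloro is separated from neither, so the two steps measured here do not add a third clearly distinct level. Against the pyridin-3-yl group of the core of compound 1, the 4-chlorophenyl group gives a 1.4-fold lower number from compound 1 to compound 4 (0.16 log units; within the scatter), so an exchange of the whole aromatic group need not leave the scatter, unlike the 4-ethylphenyl exchange in a 2.6-fold lower number from compound 1 to compound 2 (0.41 log units; beyond the scatter); no measurement is available that would explain these numbers.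

From the compounds shown here alone, whether an amine, a carboxylic acid or a chain longer than ethyl on this aromatic carbon would stay within the span of these four compounds remains open. Within the data shown here, also open is whether the lower number of the ethyl compound is particular to ethyl or is shared by other carbon chains, since ethyl is the only such group here.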